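Fluoro in Place of Hydrogen on the Anilide Ring

The compounds below may be only part of what the source reports. "The series", "measured", "known", "first", "only" and "open" are said of these compounds alone.

Three compounds have been measured in a functional assay on NCI-H1299 cells (Homo sapiens) for inhibition, read by CCK-8 assay, with a stated time of 72 h, tested at 1 uM; on this read-out higher numbers stand for more inhibition of growth at the one concentration tested and lower numbers for less inhibition of growth:

compound 1, `CN(C)C(=O)c1cc2cnc(Nc3ccc(NC(=O)C4(C(=O)Nc5ccccc5)CC4)cc3)nc2n1C1CCCC1`, gives 71.2%
compound 2, `CN(C)C(=O)c1cc2cnc(Nc3ccc(NC(=O)C4(C(=O)Nc5ccc(Cl)c(C(F)(F)F)c5)CC4)cc3)nc2n1C1CCCC1`, gives 39.5%
compound 3, `CN(C)C(=O)c1cc2cnc(Nc3ccc(NC(=O)C4(C(=O)Nc5cccc(Cl)c5)CC4)cc3)nc2n1C1CCCC1`, gives 47.9%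

Compound 1 stands highest of these three numbers, and both steps away from it point downward: a number 31.7 percentage points lower from compound 1 to compound 2 (beyond the scatter), and a number 23.3 percentage points lower from compound 1 to compound 3 (beyond the scatter). Between the two substituted compounds the difference is small: a number 8.4 percentage points higher from compound 2 to compound 3 (within the scatter).

Compound 4, `CN(C)C(=O)c1cc2cnc(Nc3ccc(NC(=O)C4(C(=O)Nc5cccc(F)c5)CC4)cc3)nc2n1C1CCCC1`, differs from compound 1 in one place: fluoro in place of hydrogen on an aromatic carbon. Within the data shown here, of the measured steps, the closest guide is the one from compound 1 to compound 3, where a single halogen entered the same ring on an aromatic carbon and the number fell beyond the scatter, as a number 23.3 percentage points lower from compound 1 to compound 3 (beyond the scatter) shows. The larger drop a number 31.7 percentage points lower from compound 1 to compound 2 (beyond the scatter) came with two groups entering at once and so speaks less directly to a single fluoro. Among the measured compounds shown here, no measured step tests fluoro itself, so the size of its effect is uncertain; a drop in this assay is expected, probably no larger than the chloro step and possibly within the scatter.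

Compound 4 is therefore estimated at 58%, in a range from 44% to 72%. This estimate means an expected step of a number 13.2 percentage points lower from compound 1 to compound 4 (beyond the scatter).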

Compound 4, percent growth inhibition at one concentration: 64.2%
Beside the measured number, compound 4's estimate is 6.2 percentage points below it; low and high end bracket the measured number.
By their numbers in this assay, from the lowest: compounds 2 and 3 (each within the scatter of the next); then compounds 4 and 1 (each within the scatter of the next).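

In this assay, the aromatic carbon that took chloro in compound 3 also accepts fluoro, and the change from the unsubstituted phenyl stays within the scatter: a number 7 percentage points lower from compound 1 to compound 4 (within the scatter). The earlier compounds shown here showed only falling numbers when halogen-bearing rings replaced phenyl, but the comparison between the two single halogens now shows that the choice of halogen matters at this place: a number 16.3 percentage points higher from compound 3 to compound 4 (beyond the scatter). The 3-fluorophenyl compound also stands clear of the ring carrying both chloro and trifluoromethyl, with a number 24.7 percentage points higher from compound 2 to compound 4 (beyond the scatter), so adding a substituent to this ring does not by itself bring a drop beyond the scatter.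

As far as these compounds go, it remains open whether bromo, methyl, methoxy or an amino group on the same aromatic carbon would stay close to compound 1 or fall towards compound 3, and whether fluoro would behave the same way on another carbon of this ring. Nothing available here speaks to the reason that fluoro and chloro part ways on this carbon.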